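Nitro for methoxycarbonyl on the biphenyl diamide series

The source may report more compounds than this note shows. Statements on the series, on what has been measured and on what is new or still open speak of the compounds shown alone.

Two members of this series have been measured in an assay on cells for inhibition of CD40-CD40L (Homo sapiens), read by reporter gene assay and spectrophotometry, with a stated time of 18 h; on this read-out higher numbers stand for weaker inhibition and lower numbers for stronger inhibition. Compound 2 `COC(=O)c1ccc(C(=O)Nc2ccc(-c3ccc(C(=O)Nc4cccc5cccc(S(=O)(=O)O)c45)cc3)cc2)cc1` gives 17100 nM in this assay. Compound 1 `O=C(Nc1ccc(-c2ccc(C(=O)Nc3ccc(C(=O)O)c4ccccc34)cc2)cc1)c1ccc([N+](=O)[O-])cc1` carries a nitro group at the outer end and a carboxylic acid on its naphthyl amide; in this assay compound 1 gives 9400 nM, a value that lies within the usual scatter of the value of compound 2, so no order between the two can be claimed.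

Compound 3 `O=C(Nc1ccc(-c2ccc(C(=O)Nc3cccc4cccc(S(=O)(=O)O)c34)cc2)cc1)c1ccc([N+](=O)[O-])cc1` has not yet been measured in this assay. It differs from compound 2 by nitro in place of methoxycarbonyl on an aromatic carbon. Within the data shown here, no measured pair covers this exchange directly. Since compound 1, which also carries the nitro group, gives 9400 nM, the step is expected to stay inside the scatter, with no direction beyond it; the expected step from compound 2 to compound 3 is a 1.4-fold lower number from compound 2 to compound 3 (0.15 log units; within the scatter). Compound 3 is therefore expected to give about 12000 nM in this assay, estimated between 5000 nM and 30000 nM.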

Compound 3, half-maximal inhibitory concentration in the CD40-CD40L assay: 10300 nM
The estimate for compound 3 lay 1.2-fold (0.07 log units) above the measured number; measured number inside the range.
By their numbers in the CD40-CD40L assay, from the lowest: compounds 1, 3 and 2 (each within the scatter of the next).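

In the CD40-CD40L assay this position now has a direct pair: nitro in place of methoxycarbonyl, on an aromatic carbon para to a large group, gives a 1.7-fold lower number from compound 2 to compound 3 (0.22 log units; within the scatter), so no difference in inhibition can be read from this exchange. In a physicochemical assay for solubility (a lower number here means a less soluble compound, a higher number a more soluble compound), compound 2 gives 240000 nM and compound 3 gives 7000 nM. In the physicochemical assay the same exchange gives a 34-fold lower number from compound 2 to compound 3 (1.54 log units; beyond the scatter), a large step. The position thus separates the two groups on solubility and not on inhibition, with methoxycarbonyl the more soluble member of this pair: the measured solubility of compound 2, 240000 nM, and of compound 3, 7000 nM, a 34-fold lower number (1.54 log units; beyond the scatter)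

Only one exchange at this position is shown, so how an amine or a nitrile there would read in either assay remains open. Also open, from the compounds shown here alone, is whether the same exchange behaves alike when the sulfonic acid of compound 2 and compound 3 is replaced by a carboxylic acid.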